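The source may hold more compounds than are shown below. What is called first, only, known or untested is meant among the compounds shown, and "the series" means these compounds.

Measured compounds:
Compound 1, `C#CCSc1nc(Sc2nnnn2CCN(C)C)c(C#N)c(-c2cccc(Cl)c2)n1`, in a functional assay on PC-9 cells (Homo sapiens) for antiproliferative activity, read by MTT assay (a higher number here means a weaker inhibitor, a lower number a stronger inhibitor), gives 6480 nM.
Compound 2, `C#CCSc1nc(Sc2nc3ccccc3s2)c(C#N)c(-c2cc(OC)c(OC)c(OC)c2)n1`, gives in this assay > 20000 nM, a limit of the assay rather than a number.
Compound 3, `C=CC(=O)Nc1ccccc1CN(C(=O)Nc1cccc(C(F)(F)F)c1)C1CCN(C(C)CCC)CC1`, gives in this assay 5590 nM.

Compound 2 stands at the limit of this assay; that limit is the limit of > 20000 nM in this assay, at which 1 of the 3 values shown sits, and so its true potency is known only to lie beyond the numbers measured here. Compound 4, `C#CCSc1nc(Sc2nncs2)c(C#N)c(-c2cc(OC)c(OC)c(OC)c2)n1`, differs from compound 2 in one place: 1,3,4-thiadiazol-2-yl in place of 1,3-benzothiazol-2-yl on a sulfur. Among the compounds with values here, compound 1 and compound 3, with different cores and substituents, both give numbers rather than limits, but no step between any pair of measured compounds is recorded, so the size of the change from a benzothiazolyl to a thiadiazolyl on that sulfur cannot be read from the data. Since compound 2 is known only as a limit, the step to compound 4 cannot be counted in either direction; it is estimated here as an at least 1.3-fold lower number from compound 2 to compound 4 (0.12 log units; that floor lies within the scatter), which means a move toward the measurable range that may or may not clear the scatter. Compound 4 is accordingly expected to give about 15000 nM, with a range from 4000 nM to 40000 nM.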

Compound 4, half-maximal inhibitory concentration: 7960 nM
Compound 4: middle estimate off by 1.9-fold (0.28 log units), on the high side; measured number inside the range.
By their numbers in this assay, from the lowest: compounds 3, 1 and 4 (each within the scatter of the next). At a limit, above all of these: compound 2.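

In this assay, compound 2 gives > 20000 nM, which is a limit of the assay and not a number. Exchanging 1,3-benzothiazol-2-yl for 1,3,4-thiadiazol-2-yl on a sulfur whose other neighbour is aromatic carbon gives an at least 2.5-fold lower number from compound 2 to compound 4 (0.40 log units; beyond the scatter), the only step among the compounds shown, and so it is the first sign that the group at this place can move the number beyond the scatter and bring a compound into the measurable range. That step is a floor and not a full size, because its starting point is a limit: the limit of > 20000 nM in this assay, at which 1 of the 4 values shown sits.

This single pair cannot separate the loss of the six-membered aromatic ring of carbon from the gain of a hetero atom in the five-membered ring, since the two groups differ in both at once. It also leaves open how far the number would move with a plain phenyl ring, a pyridin-2-yl group or a chain ending in a carboxylic acid on that sulfur, and whether the step would hold on a core carrying a different aryl group.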